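The source may report more compounds than this note shows. Statements on the series, on what has been measured and on what is new or still open speak of the compounds shown alone.

Compound 1: `Cn1cncc1C(OCc1ccc(C#N)cc1-c1ccc(F)c(Cl)c1)c1ccc(C#N)nc1`, 8600 nM
Compound 2: `Cn1cncc1C(OCc1ccc(C#N)nc1-c1cc(Cl)cc(Cl)c1)c1ccc(C#N)cc1`, 1400 nM

Both compounds were tested in an assay on isolated protein (Bos taurus) for inhibition of geranylgeranyl transferase type-1 subunit beta (Homo sapiens); on this read-out higher numbers stand for weaker inhibition and lower numbers for stronger inhibition. Compound 1 gives 8600 nM, the higher of the two numbers, and compound 2 gives 1400 nM, a gap that lies beyond the scatter. Compound 3, `Cn1cncc1C(OCc1ccc(C#N)cc1-c1cccc2ccccc12)c1ccc(C#N)nc1`, has not yet been measured. It differs from compound 1 in one place: naphthalen-1-yl in place of 3-chloro-4-fluorophenyl on an aromatic carbon. Within the data shown here, no pair of measured compounds shows this change, so the expectation rests only on the two values shown. A moderate step toward a lower number is expected, a 2.2-fold lower number from compound 1 to compound 3 (0.33 log units; beyond the scatter). Compound 3 is estimated at 4000 nM, with a range from 1500 nM to 12000 nM.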

Compound 3, half-maximal inhibitory concentration: > 10 nM
Compound 3: a limit, no number; the forecaster's own chance of this, stated with the estimate: 5%; the middle value does not contradict the limit.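

In this assay, among these compounds, compound 3 gives > 10 nM, which is a limit and not a number, so no step from compound 1 to compound 3 can be read. The compounds shown leave open how naphthalen-1-yl compares with 3-chloro-4-fluorophenyl on this read-out.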